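Cytotoxicity in a fused bicyclic series: pyridyl to lactam swap

The compounds below may be only part of what the source reports. "The series", "measured", "known", "first", "only" and "open" are said of these compounds alone.

Compound 1 `O=S(=O)(Cc1nc(-c2ccncc2)c2sccc2n1)c1cccc(Cl)c1` is the reference point for this step. In an ADME assay on cells (Homo sapiens) for cytotoxicity, read by resazurin assay, with a stated time of 5 days (a lower number here means that less compound is tolerated, a higher number that more compound is tolerated), compound 1 gives only a limit of > 50000 nM, not a number. Two further members of the series are measured. Compound 2 `COc1ccc(-c2nc(CC(=O)c3cccc(Cl)c3)nc3ccsc23)cn1` gives 30000 nM in this assay. Compound 3 `COc1ccc(-c2nc(/C=C\c3cccc(Cl)c3)nc3ccsc23)cn1` gives 53000 nM in this assay. Among the measured compounds shown here, no pair of measured compounds differs in a single place, so no measured step is known; the only evidence is the limit of > 50000 nM in this assay, at which 1 of the 3 values shown sits, which places compound 1 at the upper edge of what this assay reports.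

Compound 4 `O=c1ccc(-c2nc(CS(=O)(=O)c3cccc(Cl)c3)nc3ccsc23)c[nH]1` is not yet measured. It differs from compound 1 as follows: a group of 7 heavy atoms (5 carbon, 1 nitrogen, 1 oxygen; one six-membered aromatic ring with 1 hetero atom) in place of a group of 6 heavy atoms (5 carbon, 1 nitrogen; one six-membered aromatic ring with 1 hetero atom), on an aromatic carbon. The entering group brings one hydrogen-bond donor where the pyridin-4-yl group had none.

Across compounds 1 to 3 the values in this assay are all high, and the change to compound 4 is small, so no step beyond the scatter is expected; the expected step from compound 1 to compound 4 is a number no higher from compound 1 to compound 4 (the limit leaves the size open). For compound 4 the estimated value in this assay is 50000 nM, within a range from 20000 nM to 100000 nM.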

Compound 4, half-maximal cytotoxic concentration: > 50000 nM
Compound 4 gave a limit, no number; the forecaster's own chance of this, stated with the estimate: 55%; the middle value lies on the limit itself.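

Compound 1 and compound 4 both stand at a limit, not a number, in this assay, so no step between them can be read: the limit of > 50000 nM in this assay, at which 2 of the 4 values shown sit.

The compounds shown leave open whether the group entering in place of pyridin-4-yl changes cytotoxicity at all, and in which direction.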